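This account rests on a few compounds, and the source may have more. Where it says the series, first, only, none or still open, it means among the compounds named here.

Measured in an assay on Sf9 cells for inhibition of histone-lysine N-methyltransferase EZH2 (Homo sapiens), read by scintillation counting, in the presence of a further agent that is not named here; on this read-out lower numbers stand for stronger inhibition and higher numbers for weaker inhibition:
compound 1 `Nc1ncnc2c1ncn2[C@@H]1O[C@H](CSCC[C@H](N)C(=O)NCC2CC2)[C@@H](O)[C@H]1O` gives 60000 nM
compound 2 `Nc1ncnc2c1ncn2[C@@H]1O[C@H](CSCC[C@H](N)C(=O)NCc2cnn(-c3ccc(F)cc3)c2)[C@@H](O)[C@H]1O` gives 1400 nM

Compound 2 holds the lower of the two numbers. Among the measured compounds shown here, the only measured step is a 43-fold lower number from compound 1 to compound 2 (1.63 log units; beyond the scatter), a large gain. Compound 3 `Cn1nc(CNC(=O)[C@@H](N)CCSC[C@H]2O[C@@H](n3cnc4c(N)ncnc43)[C@H](O)[C@@H]2O)cc1C1CCC1` differs from compound 2 by a group of 10 heavy atoms (8 carbon, 2 nitrogen; one four-membered non-aromatic ring of carbon only, one five-membered aromatic ring with 2 hetero atoms) in place of a group of 12 heavy atoms (9 carbon, 2 nitrogen, 1 fluorine; one five-membered aromatic ring with 2 hetero atoms, one six-membered aromatic ring of carbon only), on a saturated chain carbon bound to an amide-type nitrogen. That measured step bears on this only in part: the five-membered aromatic ring with 2 hetero atoms that arrived in it stays in compound 3, while the six-membered aromatic ring of carbon only with its fluorine gives way to a four-membered non-aromatic ring of carbon only. Part of the gain is expected to be lost. Compound 3 is estimated at 3500 nM, with a range of 1000 nM to 12000 nM. The expected step is a 2.5-fold higher number from compound 2 to compound 3 (0.40 log units; beyond the scatter), toward a higher number.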

Compound 3, half-maximal inhibitory concentration: 40000 nM
Compound 3: middle estimate off by 11-fold (1.06 log units), on the low side; the whole stated range lies below it.
By their numbers in this assay, from the lowest: compound 2; then compounds 3 and 1 (each within the scatter of the next).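

The five-membered aromatic ring with 2 hetero atoms, on the saturated chain carbon bound to an amide-type nitrogen, does not secure the gain by itself: the change of group gives a 29-fold higher number from compound 2 to compound 3 (1.46 log units; beyond the scatter) and is a large loss. The other step is a 1.5-fold lower number from compound 1 to compound 3 (0.18 log units; within the scatter) and shows no gain over the three-membered ring group, even with that five-membered ring kept. Nothing given here explains this loss.

Open, going by these compounds, is whether the six-membered aromatic ring, its fluorine or the four-membered ring accounts for the difference. An unsubstituted phenyl group or a methoxyphenyl group on the same five-membered ring would help separate these.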